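Series notes: from methylamino to dimethylamino on the shared core

The source may report more compounds than this note shows. Statements on the series, on what has been measured and on what is new or still open speak of the compounds shown alone.

Going by the values given here, the three measured members share one core and differ at a single aromatic carbon. Compound 1 `Nc1nc2c(nc(Cl)n2COCCO)c(=O)[nH]1` carries chloro there; in a functional assay on L1210 cells (Mus musculus) for inhibition (a higher number here means a weaker inhibitor, a lower number a stronger inhibitor), compound 1 gives 350 ug/mL. Compound 2 `Nc1nc2c(nc(I)n2COCCO)c(=O)[nH]1` carries iodo; in this assay compound 2 gives 39 ug/mL, and the step of a 9.0-fold lower number from compound 1 to compound 2 (0.95 log units; beyond the scatter) is the only one in the set that lowers the number beyond the scatter. Compound 3 `CNc1nc2c(=O)[nH]c(N)nc2n1COCCO` carries methylamino. For compound 3 the read-out in this assay is a limit of the assay, > 500 ug/mL, not a number. The step of an at least 12-fold higher number from compound 2 to compound 3 (1.10 log units; beyond the scatter) lies beyond the scatter, whereas an at least 1.4-fold higher number from compound 1 to compound 3 (0.15 log units; that floor lies within the scatter) does not.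

Compound 4 `CN(C)c1nc2c(=O)[nH]c(N)nc2n1COCCO` differs from compound 3 by methyl in place of hydrogen on a nitrogen on an aromatic ring. Among the compounds with values here, none of the measured steps touches this nitrogen; each replaces the whole group on the aromatic carbon, so none bears directly on a methyl added to methylamino. With compound 3 already at a limit, the step that the limit leaves unreadable from compound 3 to compound 4 is expected to be none beyond the scatter. Compound 4 is expected to return about 600 ug/mL, between 200 ug/mL and 1800 ug/mL, and the report may again be only a limit.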

Compound 4, concentration for 50% inhibition: > 500 ug/mL
Compound 4 was reported as a limit; the forecaster's own chance of this, stated with the estimate: 65%; the middle value does not contradict the limit.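

In this assay compound 4 gives > 500 ug/mL, a limit of the assay and not a number. The added methyl on the nitrogen cannot be read from compound 3 to compound 4, since both sit at the same limit: the limit of > 500 ug/mL in this assay, at which 2 of the 4 values shown sit.

Dimethylamino in place of iodo gives an at least 12-fold higher number from compound 2 to compound 4 (1.10 log units; beyond the scatter), while dimethylamino in place of chloro gives an at least 1.4-fold higher number from compound 1 to compound 4 (0.15 log units; that floor lies within the scatter), so dimethylamino repeats the picture given by methylamino, with only the iodo compound separated beyond the scatter.

As far as these compounds go, how far compound 3 and compound 4 lie past the limit stays open, so any difference between methylamino and dimethylamino remains hidden. Also open, from the compounds shown here alone, is whether a plain amino group or bromo on this aromatic carbon would give a readable number on the shared core.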